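This account rests on a few compounds, and the source may have more. Where it says the series, first, only, none or still open, it means among the compounds named here.

In a physicochemical assay for solubility, using the shake flask method, in phosphate buffer, measured as kinetic solubility, with a stated time of 20 h, at pH 6.5 (a lower number here means a less soluble compound, a higher number a more soluble compound), compound 1 `FC(F)(F)c1cccc(-c2nc3cnc(Nc4cccnn4)cc3[nH]2)c1` gives < 5000 nM, which is a limit of the assay rather than a number. Within the data shown here, compound 2 `O=C(O)c1ccc(Nc2cc3[nH]c(-c4cccc(C(F)(F)F)c4)nc3cn2)nc1` gives 6000 nM in this assay, the only true number among the two values shown. The step of an at least 1.2-fold higher number from compound 1 to compound 2 (0.07 log units; that floor lies within the scatter) swaps one ring on the aromatic nitrogen for another. Compound 3 `NC(=O)c1ccc(Nc2cc3[nH]c(-c4cccc(C(F)(F)F)c4)nc3cn2)nc1` differs from compound 2 by amino in place of hydroxy on a carbonyl carbon. Among the measured compounds shown here, no measured step swaps these two groups, and the single measured step rests on a limit (the limit of < 5000 nM in this assay, at which 1 of the 2 values shown sits), so no shift beyond the scatter is expected. Compound 3 is estimated at 3500 nM in this assay, within 1000 nM to 10000 nM. That estimate means an expected 1.7-fold lower number from compound 2 to compound 3 (0.23 log units; within the scatter).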

Compound 3, solubility: < 5000 nM
Compound 3: a limit, no number; the forecaster's own chance of this, stated with the estimate: 45%; the middle value lies beyond the limit too.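

In this assay, amino in place of hydroxy on this carbonyl carbon gives an at least 1.2-fold lower number from compound 2 to compound 3 (0.07 log units; that floor lies within the scatter), so carboxy to carbamoyl shows no readable change beyond the scatter. The step from the pyridazin-3-yl compound to the 5-carbamoylpyridin-2-yl compound cannot be read. The value of compound 3 is a limit, not a number, so the true size of this change stays unknown: the limit of < 5000 nM in this assay, at which 2 of the 3 values shown sit.

From the compounds shown here alone, how far the value moves with methylamino or methoxy on the same carbonyl carbon remains open. So does whether either group would give a true number rather than a limit.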